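This account rests on a few compounds, and the source may have more. Where it says the series, first, only, none or still open, it means among the compounds named here.

Of the compounds shown here, three built on one shared core have been tested in a functional assay on Ehrlich cells (Mus musculus) for cytotoxicity, read by trypan blue exclusion, with a stated time of 2 h, tested at 100 ug/mL; on this read-out lower numbers stand for a weaker effect and higher numbers for a stronger effect at the one concentration tested. Compound 1, `N#CC1=C(N)N(c2ccc(S(N)(=O)=O)cc2)C2=C(C(=O)CCC2)C1c1ccc(Cl)cc1Cl`, gives 95%. Compound 2, `CC(Cl)CC(=O)NC1=C(C#N)C(c2ccc(Cl)cc2Cl)C2=C(CCCC2=O)N1c1ccc(S(N)(=O)=O)cc1`, gives 60%, and compound 3, `NC(=O)C1=C(N)N(c2ccc(S(N)(=O)=O)cc2)C2=C(C(=O)CCC2)C1c1ccc(Cl)cc1Cl`, gives 45%. Each change made so far has cost activity: a number 35 percentage points lower from compound 1 to compound 2 (beyond the scatter), and a number 50 percentage points lower from compound 1 to compound 3 (beyond the scatter). Compound 3 therefore stands lowest of the three, clearly below compound 2 and far below compound 1.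

Compound 4, `NC1=C(C(=O)O)C(c2ccc(Cl)cc2Cl)C2=C(CCCC2=O)N1c1ccc(S(N)(=O)=O)cc1`, differs from compound 3 in one place: hydroxy in place of amino on a carbonyl carbon. Going by the values given here, no measured step matches this exchange. The step from compound 1 to compound 3 sits on the same carbonyl carbon, but swaps a different pair of groups, so it cannot say how hydroxy against amino will read. Both known steps were large drops, yet each describes another change, and the data give no direct guide here. The expected step of a number 5 percentage points lower from compound 3 to compound 4 (within the scatter) in this assay is therefore none beyond the scatter, with a wide band around it. Compound 4 is estimated at 40%, within 15% to 65%.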

Compound 4, a percentage reported as activity, at one concentration (the size of the read-out at that concentration, not a potency): 60%
Beside the measured number, compound 4's estimate is 20 percentage points below it; measured number inside the range.
By their numbers in this assay, from the lowest: compound 3; then compounds 2 and 4 (each within the scatter of the next); then compound 1.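

Hydroxy in place of amino on a carbonyl carbon gives a number 15 percentage points higher from compound 3 to compound 4 (beyond the scatter) in this assay, so the group on this carbonyl carbon affects the read-out, and the carboxy group reads higher here than the carbamoyl group. Even so, carboxy in place of cyano gives a number 35 percentage points lower from compound 1 to compound 4 (beyond the scatter), so neither carbonyl-bearing group shown at this place matches the nitrile of compound 1. The data shown offer no measurement that explains either step.

The compounds shown leave open how a methyl ester or a methyl amide would read on this double-bonded ring carbon, which would show whether the free hydroxy or amino matters. As far as these compounds go, it also remains open whether the (2-chloropropyl)carbonyl group on the amine nitrogen would lower the activity of compound 4 as it does that of compound 1.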